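Chloro in place of methyl: an open step

The source may hold more compounds than are shown below. What is called first, only, known or untested is meant among the compounds shown, and "the series" means these compounds.

Compound 1 (`CC(=C\c1ccccc1)/C=C1\CCC=CC1=O`) gives 5200 nM
Compound 2 (`Cc1ccc(/C=C/C=C2\CCC=CC2=O)cc1`) gives 8100 nM

Both values were read in a functional assay on HGC-27 cells (Homo sapiens) for cytotoxicity, read by MTT assay, with a stated time of 72 h (a lower number here means a stronger inhibitor, a higher number a weaker inhibitor), and compound 2 stands within the scatter of compound 1. Compound 3 (`O=C1C=CCC/C1=C\C=C\c1ccc(Cl)cc1`) differs from compound 2 by chloro in place of methyl on an aromatic carbon, para to a large group (chloro in place of methyl on an aromatic carbon). Among the compounds with values here, no measured step shows what this exchange does. In this assay the expected 1.2-fold lower number from compound 2 to compound 3 (0.10 log units; within the scatter) is therefore estimated to stay within the scatter, in neither direction. The estimate for compound 3 is 6500 nM as the expected value, with an estimated range from 2500 nM to 17000 nM around it.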

Compound 3, half-maximal inhibitory concentration: 4800 nM
Estimate against measurement, compound 3: 1.4-fold (0.13 log units) above; measured number inside the range.
By their numbers in this assay, from the lowest: compounds 3, 1 and 2 (each within the scatter of the next).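

In this assay, within the data shown here, the exchange of methyl for chloro on an aromatic carbon, para to a large group, gives a 1.7-fold lower number from compound 2 to compound 3 (0.23 log units; within the scatter) and thus supplies the first measured step at this position. Across this one pair, the two groups cannot be told apart. No measurement shown offers an explanation for this result. The compounds shown leave open whether an amine, a carboxylic acid or a methoxy group at this place would also stay within the scatter. They also leave open how chloro would read at another carbon of the same ring.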